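Lengthening an Alkyl Chain and Its Lipophilicity

The source may report more compounds than this note shows. Statements on the series, on what has been measured and on what is new or still open speak of the compounds shown alone.

Compound 1 `CCc1ccc2[nH]c(-c3ccccc3)c(C3=C(Br)C(=O)NC3=O)c2c1` carries an ethyl chain, and in a physicochemical assay for lipophilicity (on this read-out higher numbers stand for higher lipophilicity and lower numbers for lower lipophilicity), compound 1 gives 3.15. Compound 2 `CCCc1ccc2[nH]c(-c3ccccc3)c(C3=C(Br)C(=O)NC3=O)c2c1` differs from it by methyl in place of hydrogen on a saturated chain carbon, two bonds along the chain from an aromatic carbon, and in this assay compound 2 gives 3.43; this step is a number 0.28 log units higher from compound 1 to compound 2 (within the scatter). Compound 3 `CCCCc1cccc2c(C3=C(Br)C(=O)NC3=O)c(-c3ccccc3)[nH]c12` carries a butyl chain on a differently built core; how its core differs from that of compound 1 is not broken down here. In this assay compound 3 gives 3.88, the highest of the three. Compound 4 `CCCCCc1cccc2c(C3=C(Br)C(=O)NC3=O)c(-c3ccccc3)[nH]c12` differs from compound 3 by methyl in place of hydrogen on a saturated chain carbon, four bonds along the chain from an aromatic carbon. This is the same kind of change as between compound 1 and compound 2, but the added carbon sits four bonds along the chain from an aromatic carbon rather than two. Because the earlier change gave a number 0.28 log units higher from compound 1 to compound 2 (within the scatter), a step of similar size is expected here: a number 0.37 log units higher from compound 3 to compound 4 (beyond the scatter). Compound 4 is therefore estimated at 4.25.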

Compound 4, partition coefficient: 4.11
For compound 4 the middle estimate is 0.14 log units above the measured one; the range from low to high includes it.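

In this assay the same change of methyl in place of hydrogen gives a number 0.23 log units higher from compound 3 to compound 4 (within the scatter) and, on the other core, a number 0.28 log units higher from compound 1 to compound 2 (within the scatter). Both steps lie within the scatter, so this shows that the change stays within the scatter on both cores, but it does not show a real rise on either core or that a rise carries from one core to the other. The added carbon also sits at a different place along the chain in the two steps, and no measurement shown gives a cause for either step.

The compounds shown leave open whether an ethyl chain and a butyl chain would read alike on the two cores. They also leave open how a longer chain, or a chain ending in an amine or a carboxylic acid, would read in this assay.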